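Ring size at the ether: compound 2 to compound 4

The compounds below may be only part of what the source reports. "The series", "measured", "known", "first", "only" and "open" are said of these compounds alone.

Compound 2 `NC(=O)[C@@H](CCC(F)(F)F)N(C[C@@H]1CCCCO1)S(=O)(=O)c1ccc(Cl)cc1` stands only at a limit of the assay: in an in vitro ADME assay on microsomes from liver (Homo sapiens) for metabolic stability, read by HPLC (a higher number here means faster removal of the compound, a lower number slower removal), compound 2 gives > 300 mL/min/kg. Compound 1 `NC(=O)[C@@H](CCC(F)(F)F)N(C[C@H]1CCCCO1)S(=O)(=O)c1ccc(Cl)cc1` likewise sits at a limit, giving > 300 mL/min/kg. Compound 3 `NC(=O)[C@@H](CCC(F)(F)F)N(C[C@@H]1CCCOC1)S(=O)(=O)c1ccc(Cl)cc1` gives 136 mL/min/kg. The step that the two limits leave unreadable from compound 1 to compound 2 stays unreadable due to the limit of > 300 mL/min/kg in this assay, at which 2 of the 3 values shown sit, and (the fact that compounds 1 and 2 differ only in the configuration as drawn). The steps of an at least 2.2-fold lower number from compound 1 to compound 3 (0.34 log units; beyond the scatter) and an at least 2.2-fold lower number from compound 2 to compound 3 (0.34 log units; beyond the scatter) both move the attachment point of the ring, not its size. Compound 4 `NC(=O)[C@@H](CCC(F)(F)F)N(C[C@H]1CCO1)S(=O)(=O)c1ccc(Cl)cc1` differs from compound 2 by oxetan-2-yl in place of oxan-2-yl on a saturated chain carbon bound to a sulfonamide nitrogen. Among the measured compounds shown here, no measured step changes ring size, so the expectation rests on compound 2 at its limit alone. The step of an at least 1.3-fold lower number from compound 2 to compound 4 (0.13 log units; that floor lies within the scatter) is expected to be modest, downward if anything. Compound 4 is estimated at 220 mL/min/kg, between 90 mL/min/kg and 450 mL/min/kg.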

Compound 4, clearance: 63.8 mL/min/kg
The estimate for compound 4 lay 3.4-fold (0.54 log units) above the measured number, outside the stated range (below it).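

A change of ring size on this saturated chain carbon can now be read in this assay, though only as floors, with an at least 4.7-fold lower number from compound 2 to compound 4 (0.67 log units; beyond the scatter) and an at least 4.7-fold lower number from compound 1 to compound 4 (0.67 log units; beyond the scatter) both resting on a limit of the assay: the limit of > 300 mL/min/kg in this assay, at which 2 of the 4 values shown sit. Among the compounds shown here, the one step between two real numbers is a 2.1-fold lower number from compound 3 to compound 4 (0.33 log units; beyond the scatter), which makes compound 4 the lowest of the four and shows that oxetan-2-yl gives a lower number than oxan-3-yl here.

From the compounds shown here alone, whether the number falls steadily with ring size stays open, as an oxolan-2-yl group would show. The mirror-image oxetan-2-yl partner of compound 4 and an open-chain methoxyethyl group also remain to be compared.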